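This account rests on a few compounds, and the source may have more. Where it says the series, first, only, none or still open, it means among the compounds named here.

Measured in an assay on isolated protein for inhibition of A disintegrin and metalloproteinase with thrombospondin motifs 5 (Homo sapiens), read by spectrophotometry, with stated times of 10 min and 3 h; on this read-out higher numbers stand for weaker inhibition and lower numbers for stronger inhibition:

compound 1 `O=C(COc1ccccc1)NNC(=S)NCc1ccc(-c2ccccc2)cc1` — 10000 nM
compound 2 `O=C(COc1ccc(C(F)(F)F)cc1)NNC(=S)NCc1ccc(-c2ccccc2)cc1` — 1700 nM
compound 3 `O=C(COc1ccccc1Cl)NNC(=S)NCc1ccc(-c2ccccc2)cc1` — 1900 nM

Compound 3 stands second highest of the three numbers. Its nearest neighbour is compound 2, the step of a 1.1-fold higher number from compound 2 to compound 3 (0.05 log units; within the scatter) lying within the scatter; its furthest is compound 1, from which a 5.3-fold lower number from compound 1 to compound 3 (0.72 log units; beyond the scatter).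

The next compound in the series is compound 4 `O=C(COc1cccc(Cl)c1)NNC(=S)NCc1ccc(-c2ccccc2)cc1`. The change from compound 3 is 3-chlorophenyl in place of 2-chlorophenyl on an oxygen on a saturated carbon, so the same atoms are joined differently and only the point of attachment of the chlorine on the phenoxy ring moves.

For the measured compounds named here, two measured steps bear on substitution of the phenoxy ring: a 5.9-fold lower number from compound 1 to compound 2 (0.77 log units; beyond the scatter) and a 5.3-fold lower number from compound 1 to compound 3 (0.72 log units; beyond the scatter), both modest and both beyond the scatter, in the same direction. The step of a 1.1-fold higher number from compound 2 to compound 3 (0.05 log units; within the scatter) shows that exchanging one substituted phenoxy ring for another, substituent and place together, stayed within the scatter. Going by the values given here, no measured step moves a chlorine alone from one ring carbon to another, so nothing here separates the two chlorophenoxy rings.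

The expected step from compound 3 to compound 4 is therefore none beyond the scatter: a 1.1-fold lower number from compound 3 to compound 4 (0.05 log units; within the scatter). The estimate for compound 4 in this assay is 1700 nM, with a range of 700 nM to 4500 nM.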

Compound 4, half-maximal inhibitory concentration: 2100 nM
For compound 4 the middle estimate is 1.2-fold (0.09 log units) below the measured one; the measured number falls inside the stated range.
By their numbers in this assay, from the lowest: compounds 2, 3 and 4 (each within the scatter of the next); then compound 1.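

In this assay, for the compounds shown here, the chlorine alone changes place for the first time: 3-chlorophenyl in place of 2-chlorophenyl on an oxygen on a saturated carbon gives a 1.1-fold higher number from compound 3 to compound 4 (0.04 log units; within the scatter) and so does not separate these two chlorophenoxy rings. The gain from a chloro in place of hydrogen on an aromatic carbon also appears with the new placement, with a 4.8-fold lower number from compound 1 to compound 4 (0.68 log units; beyond the scatter) being modest and in the same direction as a 5.3-fold lower number from compound 1 to compound 3 (0.72 log units; beyond the scatter) for the earlier placement. Compound 4 also cannot be told apart from the trifluoromethyl compound, with a 1.2-fold higher number from compound 2 to compound 4 (0.09 log units; within the scatter) adding a third substituted phenoxy compound to the same group, all beyond the scatter from the unsubstituted phenoxy compound 1.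

Still open, going by these compounds, is whether this shared level holds for a 4-chlorophenyl ring, or for a phenoxy ring carrying an amine, a carboxylic acid or a methoxy group, or whether such groups would separate from compounds 2, 3 and 4. No evidence at hand bears on why the two chlorine placements read alike.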